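Swapping the Triazole Aryl: Methoxy Out, Hydroxyl In

The source may report more compounds than this note shows. Statements on the series, on what has been measured and on what is new or still open speak of the compounds shown alone.

Compound 1 `COc1cc(/C=C/C(C)=O)ccc1OCc1cn(-c2ccc(/N=N/c3ccccc3)cc2)nn1` gives 42100 nM in a functional assay on PC-3 cells (Homo sapiens) for antiproliferative activity, read by MTT assay, with a stated time of 48 h; a lower number here means a stronger inhibitor, a higher number a weaker inhibitor.
Compound 2 `COc1ccc(-n2cc(COc3ccc(/C=C/C(C)=O)cc3OC)nn2)cc1` gives 2010 nM in this assay.
Compound 3 `COc1cc(/C=C/C(C)=O)ccc1OCc1cn(-c2ccc(C(F)(F)F)c(C(F)(F)F)c2)nn1` gives 67200 nM in this assay.

Compound 2 stands lowest of the three, and its gaps to compound 1 and compound 3 both lie beyond the scatter, so it is the strongest inhibitor measured so far. Compound 4 `COc1cc(/C=C/C(C)=O)ccc1OCc1cn(-c2ccccc2O)nn1` keeps the shared core of compound 2 and changes only the group on the triazole: 2-hydroxyphenyl in place of 4-methoxyphenyl on an aromatic nitrogen. Among the measured compounds shown here, the one step that bears on this position is a 21-fold lower number from compound 1 to compound 2 (1.32 log units; beyond the scatter), which shows that the aryl group here can move the result a great deal; the value of compound 3 points the same way. For the measured compounds named here, with no direct precedent for a hydroxyl at this place, a moderate loss is the working guess. Compound 4 is expected to give 6000 nM, within 1500 nM to 25000 nM. This expected step is a 3.0-fold higher number from compound 2 to compound 4 (0.47 log units; beyond the scatter).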

Compound 4, half-maximal inhibitory concentration: 59200 nM
Estimate against measurement, compound 4: 9.9-fold (0.99 log units) below; the whole stated range lies below it.
By their numbers in this assay, from the lowest: compound 2; then compounds 1, 4 and 3 (each within the scatter of the next).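

The change from 4-methoxyphenyl to 2-hydroxyphenyl gives a 29-fold higher number from compound 2 to compound 4 (1.47 log units; beyond the scatter), so even a swap between two similar-sized groups, each with one six-membered aromatic ring of carbon only, can cost as much here as the larger swaps seen earlier. Compound 4 now falls within the scatter of compound 1 and compound 3, leaving compound 2 alone at the low end. Nothing measured here explains this loss. The step changes both the oxygen-bearing group and its place on the ring, so the two effects cannot be separated. The 2-methoxyphenyl and 4-hydroxyphenyl groups would pull them apart.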